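Little change expected from a 2,4-dichlorophenyl swap

A few compounds are considered here, and "the series" means these few. Any claim that something is new, unique, unknown or untested is made for them only; others in the source may bear on it.

In a functional assay on MCF7 cells (Homo sapiens) for cytotoxicity, read by MTT assay, with a stated time of 72 h (on this read-out higher numbers stand for weaker inhibition and lower numbers for stronger inhibition), compound 1 `COc1ccc(/C=C2\CCC/C(=C\c3ccccc3Cl)C2=O)cc1OC` gives 10400 nM, compound 2 `COc1ccc(/C=C2\CCC/C(=C\c3ccccc3Br)C2=O)cc1OC` gives 9500 nM and compound 3 `COc1ccc(/C=C2\CCC/C(=C\c3ccc(OC)c(OC)c3)C2=O)cc1` gives 7800 nM. These three values lie within the usual scatter of one another, so compound 3 stands level with the other two.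

Compound 4 `COc1ccc(/C=C2\CCC/C(=C\c3ccc(Cl)cc3Cl)C2=O)cc1OC` differs from compound 3 in one place, with 2,4-dichlorophenyl in place of 4-methoxyphenyl on a double-bonded chain carbon bound to a double-bonded ring carbon.

The closest guides are the measured exchanges at this same place, which run from a halogen-carrying phenyl group to 4-methoxyphenyl. They are a 1.3-fold lower number from compound 1 to compound 3 (0.12 log units; within the scatter) and a 1.2-fold lower number from compound 2 to compound 3 (0.09 log units; within the scatter), both within the scatter. Exchanging the halogen itself gave a 1.1-fold lower number from compound 1 to compound 2 (0.04 log units; within the scatter), also within the scatter. Going by the values given here, no measured compound carries the 2,4-dichlorophenyl group, so this expectation remains untested.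

The expected step is a 1.2-fold higher number from compound 3 to compound 4 (0.06 log units; within the scatter), which would be no change beyond the scatter. In this assay the estimated value for compound 4 is 9000 nM, within an expected range of 4500 nM to 18000 nM.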

Compound 4, half-maximal inhibitory concentration: 16200 nM
Compound 4: middle estimate off by 1.8-fold (0.26 log units), on the low side; low and high end bracket the measured number.
By their numbers in this assay, from the lowest: compounds 3, 2, 1 and 4 (each within the scatter of the next, the first and the last beyond it).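

Here 2,4-dichlorophenyl in place of 4-methoxyphenyl gives a 2.1-fold higher number from compound 3 to compound 4 (0.32 log units; beyond the scatter) and is the first exchange at this place to pass beyond the scatter in this assay so the group on this double-bonded chain carbon can shift the number, though only modestly. That shift appears only against compound 3, since a 1.7-fold higher number from compound 2 to compound 4 (0.23 log units; within the scatter) and a 1.6-fold higher number from compound 1 to compound 4 (0.19 log units; within the scatter) both stay within the scatter, so the added chloro in place of hydrogen on an aromatic carbon cannot be read as a real change. No evidence here accounts for any of these numbers.

Still open, going by these compounds, is whether a different kind of group at this place, such as an aminophenyl group or a benzoic acid, would move the number further. A pyridine ring in place of the phenyl ring is equally unsettled.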